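Dropping the Methoxy from the Pyridyl Ring

The source may report more compounds than this note shows. Statements on the series, on what has been measured and on what is new or still open speak of the compounds shown alone.

Compound 2 `COc1cncc(-c2c(C)nn(-c3nc(-c4ccc(Cl)c(Cl)c4)c(SC(C)C)s3)c2C(=O)O)c1` gives the highest number of the three measured compounds in a functional assay on BJAB cells (Homo sapiens) for antiproliferative activity, with a stated time of 4 days (on this read-out higher numbers stand for an effect only at larger amounts of compound and lower numbers for an effect already at smaller amounts), at 21000 nM. Compound 1 `Cc1nn(-c2nc(-c3ccc(Cl)c(Cl)c3)c(SC(C)C)s2)c(C(=O)O)c1-c1cnn(C)c1` gives 6800 nM, and compound 3 `Cc1nn(-c2nc(-c3ccc(Cl)c(Cl)c3)c(SC(C)C)s2)c(C(=O)O)c1-c1cccc(Cl)c1C` gives 5100 nM; both steps, a 3.1-fold higher number from compound 1 to compound 2 (0.49 log units; beyond the scatter) and a 4.1-fold lower number from compound 2 to compound 3 (0.61 log units; beyond the scatter), lie beyond the scatter, while a 1.3-fold lower number from compound 1 to compound 3 (0.12 log units; within the scatter) does not. Compound 4 `Cc1nn(-c2nc(-c3ccc(Cl)c(Cl)c3)c(SC(C)C)s2)c(C(=O)O)c1-c1cccnc1` differs from compound 2 by hydrogen in place of methoxy on an aromatic carbon. Among the measured compounds shown here, no measured step removes only a methoxy; the two steps that touch this position swap the whole ring, so they bear on it only loosely, showing that the other two rings at this position give lower numbers than compound 2. The step is therefore expected to be a 2.3-fold lower number from compound 2 to compound 4 (0.37 log units; beyond the scatter), and compound 4 is estimated at 9000 nM, within 4000 nM to 25000 nM.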

Compound 4, half-maximal effective concentration: 12000 nM
For compound 4 the middle estimate is 1.3-fold (0.12 log units) below the measured one, within the range that was stated.
By their numbers in this assay, from the lowest: compounds 3, 1, 4 and 2 (each within the scatter of the next, the first and the last beyond it).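

Taken alone, the methoxy counts for little here: a 1.8-fold lower number from compound 2 to compound 4 (0.24 log units; within the scatter) stays within the scatter in this assay and separates 5-methoxypyridin-3-yl from pyridin-3-yl by no clear margin. Pyridin-3-yl cannot be told from 1-methyl-1H-pyrazol-4-yl either, with a 1.8-fold higher number from compound 1 to compound 4 (0.25 log units; within the scatter) also within the scatter. Only the ring swap in a 2.4-fold higher number from compound 3 to compound 4 (0.37 log units; beyond the scatter) lies beyond it, which sets pyridin-3-yl clearly apart from 3-chloro-2-methylphenyl. From the compounds shown here alone, whether an amine or a longer chain such as ethoxy in place of the methoxy would move the number stays open. Nothing offered here accounts for any of these steps.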